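Swapping the chain on a shared nucleoside core

This account rests on a few compounds, and the source may have more. Where it says the series, first, only, none or still open, it means among the compounds named here.

Compound 1 `CN(C)CCCn1c(=O)n(C2OC(CO)[C@@H](O)[C@H]2O)c2nc(N)nc(O)c21` gives 820 uM in a functional assay with Mus musculus as the target; a lower number here means that less compound is needed, a higher number that more compound is needed for the effect.
Compound 2 `CCOC(=O)Cn1c(=O)n(C2OC(CO)[C@@H](O)[C@H]2O)c2nc(N)nc(O)c21` gives 630 uM in this assay.
Compound 3 `CCCCCCn1c(=O)n(C2OC(CO)[C@@H](O)[C@H]2O)c2nc(N)nc(O)c21` gives 600 uM in this assay.

The three compounds share one core and differ only in the chain attached to an aromatic nitrogen. The steps between them are a 1.3-fold lower number from compound 1 to compound 2 (0.11 log units; within the scatter), a 1.4-fold lower number from compound 1 to compound 3 (0.14 log units; within the scatter) and a 1.1-fold lower number from compound 2 to compound 3 (0.02 log units; within the scatter), every one within the scatter. Compound 3 has the smallest of the three numbers, but since its steps to compound 2 and compound 1 both fall within the scatter, the three compounds cannot be told apart in this assay.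

Compound 4 `NC(=O)Cn1c(=O)n(C2OC(CO)[C@@H](O)[C@H]2O)c2nc(N)nc(O)c21` is the next member. Compared with compound 3 the change is carbamoyl in place of pentyl on a saturated chain carbon bound to an aromatic nitrogen. The step that bears most on this is a 1.1-fold lower number from compound 2 to compound 3 (0.02 log units; within the scatter), where a carbonyl-bearing group was exchanged for a plain chain at the same place with no effect beyond the scatter; the other two steps also show the chain at this position hardly matters. The step from compound 3 to compound 4 is therefore expected to be a 1.2-fold higher number from compound 3 to compound 4 (0.07 log units; within the scatter), no shift beyond the scatter. Compound 4 is estimated to give 700 uM in this assay, with a range from 350 uM to 1400 uM.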

Compound 4, concentration for half-maximal effect: 117 uM
Estimate against measurement, compound 4: 6.0-fold (0.78 log units) above; the measured number lies below the stated range.
By their numbers in this assay, from the lowest: compound 4; then compounds 3, 2 and 1 (each within the scatter of the next).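

The chain on the aromatic nitrogen matters more in this assay than the first three compounds suggested: carbamoyl at this place separates compound 4 from all of them, with a 5.1-fold lower number from compound 3 to compound 4 (0.71 log units; beyond the scatter), a 5.4-fold lower number from compound 2 to compound 4 (0.73 log units; beyond the scatter) and a 7.0-fold lower number from compound 1 to compound 4 (0.85 log units; beyond the scatter). Within the data shown here, the step from compound 2 is the most telling, since the only change is amino in place of ethoxy on a carbonyl carbon, so a carbonyl at this place is not enough on its own to give the lower number seen with compound 4. The numbers show that the change matters but not how it works, and no measurement at hand explains it.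

The compounds shown leave open how much of the carbamoyl group is needed, which methylcarbamoyl and dimethylcarbamoyl at the same place would help to show, and whether a carboxylic acid there would behave like the amide or like the ester of compound 2. They also leave open whether the carbonyl must stay this close to the aromatic nitrogen, a question that a longer chain such as carbamoylethyl could address.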